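This account rests on a few compounds, and the source may have more. Where it says the series, first, only, none or still open, it means among the compounds named here.

Compounds measured in a functional assay (plasma) for inhibition, with Oryctolagus cuniculus as the target; on this read-out lower numbers stand for stronger inhibition and higher numbers for weaker inhibition:
compound 1 `O=C(O)CCC/C=C\C[C@H]1[C@@H]2CCC(C2)[C@@H]1NS(=O)(=O)c1cccc2ccccc12` gives 1100 nM
compound 2 `Cc1ccc(S(=O)(=O)N[C@H]2C3CC[C@H](C3)[C@@H]2C/C=C\CCCC(=O)O)cc1` gives 500 nM
compound 3 `CCc1ccc(S(=O)(=O)N[C@H]2C3CC[C@H](C3)[C@@H]2C/C=C\CCCC(=O)O)cc1` gives 4600 nM

Compound 3 has the highest number of the three, and both steps toward it lie beyond the scatter: a 4.2-fold higher number from compound 1 to compound 3 (0.62 log units; beyond the scatter) and a 9.2-fold higher number from compound 2 to compound 3 (0.96 log units; beyond the scatter). The whole series keeps the same bicyclic sulfonamide acid core and varies only the group on the sulfonyl sulfur.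

Compound 4 `COc1ccc(S(=O)(=O)N[C@H]2C3CC[C@H](C3)[C@@H]2C/C=C\CCCC(=O)O)cc1` is not yet measured. Relative to compound 3 the change is methoxy in place of ethyl on an aromatic carbon. Within the data shown here, no measured step exchanges ethyl for methoxy, so nothing bears on it directly. Among the measured compounds shown here, the only step at this position, a 9.2-fold higher number from compound 2 to compound 3 (0.96 log units; beyond the scatter), shows a sizeable upward movement in this assay when the group on that aromatic carbon is lengthened. Methoxy carries a hydrogen-bond acceptor where ethyl carries none, and the series holds no step that isolates such an exchange. The expectation is therefore uncertain: a modest downward step, a 3.1-fold lower number from compound 3 to compound 4 (0.49 log units; beyond the scatter), is expected, placing compound 4 somewhere between compound 2 and compound 3 rather than beyond either. Compound 4 is estimated at 1500 nM, with a range from 400 nM to 6000 nM.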

Compound 4, half-maximal inhibitory concentration: 1700 nM
For compound 4 the middle estimate is 1.1-fold (0.05 log units) below the measured one, and the stated range covers the measured number.
By their numbers in this assay, from the lowest: compound 2; then compounds 1 and 4 (each within the scatter of the next); then compound 3.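

Within this assay, the exchange of ethyl for methoxy keeps the count of heavy atoms on the aromatic carbon and replaces one carbon with one oxygen, yet the number still moves beyond the scatter (a 2.7-fold lower number from compound 3 to compound 4 (0.43 log units; beyond the scatter)), so at this position the heavy-atom count alone does not set the read-out. Methoxy does not restore the value seen with the methyl group (a 3.4-fold higher number from compound 2 to compound 4 (0.53 log units; beyond the scatter)), while the step from the naphthalen-1-yl group stays within the scatter (a 1.5-fold higher number from compound 1 to compound 4 (0.19 log units; within the scatter)), so 4-methoxyphenyl and naphthalen-1-yl cannot be told apart in this assay. No measured information on these compounds accounts for any of these steps.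

As far as these compounds go, what remains open is whether the oxygen of methoxy matters in itself, which a comparison with hydroxyl, chlorine or a longer chain such as propyl on the same aromatic carbon could help to settle. The series shown also leaves open how the unsubstituted phenyl group would stand against methyl, ethyl and methoxy, and so whether the group on that carbon helps or harms.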